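This account rests on a few compounds, and the source may have more. Where it says the series, first, only, none or still open, it means among the compounds named here.

Values in a functional assay on MCF7 cells (Homo sapiens) for antiproliferative activity, read by CCK-8 assay, with a stated time of 48 h; on this read-out higher numbers stand for weaker inhibition and lower numbers for stronger inhibition:

- Compound 1 `CNC(=O)/C=C/CN1CC(Oc2ccc(Oc3c(-c4ccc(F)cc4)sc4cc(O)ccc34)cc2)C1`: > 25000 nM (a limit of the assay, not a number)
- Compound 2 `C/C=C/C(=O)N1CC(Oc2ccc(Oc3c(-c4ccc(F)cc4)sc4cc(O)ccc34)cc2)C1`: 28000 nM
- Compound 3 `CN(C)C(=O)/C=C/CNCCOc1ccc(Oc2c(-c3ccc(F)cc3)sc3cc(O)ccc23)cc1`: 13800 nM

Of the two readable numbers, compound 3 has the lower, 13800 nM, against compound 2 at 28000 nM. The gap is a 2.0-fold lower number from compound 2 to compound 3 (0.31 log units; beyond the scatter). It is real but small, and even the better of these compounds needs a high concentration to act on the cells.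

The next compound to be measured is compound 4 `O=C(CCCNCCOc1ccc(Oc2c(-c3ccc(F)cc3)sc3cc(O)ccc23)cc1)N1CCC1`. It keeps the shared core and the aminoethyl chain of compound 3 and changes only the end of that chain: 2-((azetidin-1-yl)carbonyl)ethyl in place of 2-(dimethylcarbamoyl)ethenyl on a saturated chain carbon bound to an amine nitrogen. In short, 2-((azetidin-1-yl)carbonyl)ethyl stands in place of 2-(dimethylcarbamoyl)ethenyl on a saturated chain carbon bound to an amine nitrogen.

Among the compounds with values here, no measured step changes this group alone, so the evidence is indirect. The closest guides are a 2.0-fold lower number from compound 2 to compound 3 (0.31 log units; beyond the scatter) and an at least 1.8-fold lower number from compound 1 to compound 3 (0.25 log units; that floor lies within the scatter), and the second of these has a floor within the scatter. The step that the limit leaves unreadable from compound 1 to compound 2 gives no size at all. With so little movement among these compounds, no shift beyond the scatter is expected in this assay, and the expected step is a 1.2-fold higher number from compound 3 to compound 4 (0.06 log units; within the scatter). For compound 4 the estimated value is 16000 nM, with an expected range from 8000 nM to 32000 nM.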

Compound 4, half-maximal inhibitory concentration: > 25000 nM
Compound 4: no number, only a limit (the forecaster's own chance of this, stated with the estimate: 20%); at least 1.5-fold (0.19 log units) between middle value and limit.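

In this assay compound 4 gives > 25000 nM, which is a limit of the assay and not a number. This is the only step shown that alters the end of the aminoethyl chain alone, and it reads an at least 1.8-fold higher number from compound 3 to compound 4 (0.25 log units; that floor lies within the scatter): putting 2-((azetidin-1-yl)carbonyl)ethyl in place of 2-(dimethylcarbamoyl)ethenyl brought no gain in strength, while a floor within the scatter leaves a real loss unproven. The steps to compound 4 from the two azetidin-3-yl compounds, compound 1 and compound 2, cannot be read, and the same limit now recurs in this small set: the limit of > 25000 nM in this assay, at which 2 of the 4 values shown sit.

The swap changes two things at once, the ethenyl link giving way to a saturated ethyl link and the dimethylcarbamoyl end giving way to a carbonyl bearing azetidine, so the compounds shown cannot say which of the two matters. Also open, on these data alone, is whether another chain end, such as a pyrrolidine amide, a carboxylic acid or a longer chain, would give a readable number in this assay that differs from compound 3 beyond the scatter.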